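Swapping the group on the amine nitrogen of compound 2

The compounds below may be only part of what the source reports. "The series", "measured", "known", "first", "only" and "open" are said of these compounds alone.

- compound 1 `CC[C@H](C)[C@H](NCC(=O)NNC(=O)COc1ccc(-c2nc3ccccc3s2)cc1OC)C(=O)O` gives 3540 nM
- compound 2 `COc1cc(-c2nc3ccccc3s2)ccc1OCC(=O)NNC(=O)CN[C@@H](CCSC)C(=O)O` gives 3780 nM

In a functional assay on HepG2 cells (Homo sapiens) for inhibition, read by MTT assay, with a stated time of 3 days (on this read-out higher numbers stand for weaker inhibition and lower numbers for stronger inhibition), compound 2, at 3780 nM, cannot be told apart from compound 1. The next structure, compound 3 `CCOC(=O)[C@H](CS)NCC(=O)NNC(=O)COc1ccc(-c2nc3ccccc3s2)cc1OC`, has not been measured. It carries 1-(ethoxycarbonyl)-2-sulfanylethyl in place of 1-carboxy-3-(methylsulfanyl)propyl on an amine nitrogen. Among the compounds with values here, the one measured step, a 1.1-fold higher number from compound 1 to compound 2 (0.03 log units; within the scatter), stayed within the scatter. It is only a weak guide, as neither measured compound carries the entering group. No clear direction is expected, and the estimated step is a 1.1-fold lower number from compound 2 to compound 3 (0.06 log units; within the scatter). For compound 3 the expected value is 3300 nM, within an estimated range of 1100 nM to 10000 nM.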

Compound 3, half-maximal inhibitory concentration: 3760 nM
Estimate against measurement, compound 3: 1.1-fold (0.06 log units) below; the range from low to high includes it.
By their numbers in this assay, from the lowest: compounds 1, 3 and 2 (each within the scatter of the next).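

In this assay putting 1-(ethoxycarbonyl)-2-sulfanylethyl in place of 1-carboxy-3-(methylsulfanyl)propyl gives a 1.0-fold lower number from compound 2 to compound 3 (0.00 log units; within the scatter) and putting it in place of 1-carboxy-2-methylbutyl gives a 1.1-fold higher number from compound 1 to compound 3 (0.03 log units; within the scatter) on the same amine nitrogen. Both steps stay within the scatter, so this position now tolerates ethoxycarbonyl as well as carboxy, and a sulfanyl group as well as methylsulfanyl, with no readable change. No measured evidence accounts for this flat result. Still open, from the compounds shown here alone, is whether a quite different group on this nitrogen, such as a longer chain ending in an amine, would move the number beyond the scatter.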